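Swapping a halogenated phenyl ring on a shared piperidinone scaffold

The compounds below may be only part of what the source reports. "The series", "measured", "known", "first", "only" and "open" are said of these compounds alone.

Compound 1 `COc1cc(/C=C2\CN(C)C/C(=C\c3ccc(Br)cc3)C2=O)cc(OC)c1`: 4840 nM
Compound 2 `COc1cc(/C=C2\CN(C)C/C(=C\c3ccc(Cl)cc3Cl)C2=O)cc(OC)c1`: 6250 nM
Compound 3 `CN1C/C(=C\c2ccc(Br)cc2)C(=O)/C(=C/c2cccc([N+](=O)[O-])c2)C1`: 8800 nM

All three compounds were tested in a functional assay on HepG2 cells (Homo sapiens) for cytotoxicity, read by MTT assay, with a stated time of 24 h; a higher number here means a weaker inhibitor, a lower number a stronger inhibitor. Compound 1 and compound 2 differ in one place, by 2,4-dichlorophenyl in place of 4-bromophenyl on a double-bonded chain carbon bound to a double-bonded ring carbon. That change produced a 1.3-fold higher number from compound 1 to compound 2 (0.11 log units; within the scatter), so the two compounds are indistinguishable within the usual scatter. The difference between the core of compound 1 and the core of compound 3 is not broken down here; the two values simply stand close together, both within the scatter of each other and of compound 2.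

Compound 4 `CN1C/C(=C\c2cccc([N+](=O)[O-])c2)C(=O)/C(=C/c2ccc(Cl)cc2Cl)C1` has not yet been measured. It differs from compound 3 by 2,4-dichlorophenyl in place of 4-bromophenyl on a double-bonded chain carbon bound to a double-bonded ring carbon, which is the same change already seen between compound 1 and compound 2, at the same place. Because that earlier step gave a 1.3-fold higher number from compound 1 to compound 2 (0.11 log units; within the scatter), a similarly small step is expected here, so compound 4 is estimated to give a 1.2-fold higher number from compound 3 to compound 4 (0.08 log units; within the scatter) in this assay. The estimate rests on a single earlier example and is therefore uncertain. Compound 4 is expected to give about 10500 nM, within a range of 4500 nM to 25000 nM.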

Compound 4, half-maximal inhibitory concentration: 4800 nM
Compound 4: the middle estimate sits 2.2-fold (0.34 log units) above what was measured, and the stated range covers the measured number.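

In this assay, putting 2,4-dichlorophenyl in place of 4-bromophenyl on the core of compound 3 gave a 1.8-fold lower number from compound 3 to compound 4 (0.26 log units; within the scatter). Set beside the earlier example, this step does not differ from it by more than repeated measurements normally would: the same change on two cores in this assay, a 1.3-fold higher number (0.11 log units; within the scatter) from compound 1 to compound 2 and a 1.8-fold lower number (0.26 log units; within the scatter) from compound 3 to compound 4, 2.4-fold (0.37 log units) apart, within the scatter of two such steps. On both cores, then, the change stays within the scatter, which is consistent with it carrying over from one core to the other, but two cores are a thin basis, and steps this small cannot show whether the change has any real effect on either core or on a third.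

On these data alone, it remains open whether a phenyl ring carrying an amine or a carboxylic acid in place of the halogens would move the number beyond the scatter. As far as these compounds go, how these compounds behave outside this assay also remains open.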